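The source may hold more compounds than are shown below. What is called first, only, known or untested is meant among the compounds shown, and "the series" means these compounds.

Measured so far in a functional assay on A-431 cells (Homo sapiens) for cytotoxicity, read by MTT assay, with a stated time of 48 h; on this read-out lower numbers stand for stronger inhibition and higher numbers for weaker inhibition:
- compound 1, `CCCCCCCCCCCCCCNC(=O)[C@@H](NC(=O)c1ccccc1)[C@@H](C)O`: 118000 nM
- compound 2, `CCCCCCCCCCCCCCNC(=O)[C@@H](NC(=O)c1cccs1)[C@@H](C)O`: 26500 nM
- compound 3, `CCCCCCCCCCCCCCNC(=O)[C@@H](NC(=O)c1cc2ccccc2o1)[C@@H](C)O`: 20100 nM

Compound 3 holds the lowest number of the three; against compound 2 the gap is within the scatter, against compound 1 it is a 5.9-fold lower number from compound 1 to compound 3 (0.77 log units; beyond the scatter). Compound 4, `CCCCCCCCCCCCCCNC(=O)[C@@H](NS(=O)(=O)c1ccc(C)cc1)[C@@H](C)O`, differs from compound 3 by (4-methylphenyl)sulfonyl in place of (1-benzofuran-2-yl)carbonyl on an amine nitrogen. Within the data shown here, the measured steps, a 4.5-fold lower number from compound 1 to compound 2 (0.65 log units; beyond the scatter) and a 5.9-fold lower number from compound 1 to compound 3 (0.77 log units; beyond the scatter), each swap the aryl group while the carbonyl stays; no measured step swaps the carbonyl itself for a sulfonyl, so they bear on this change only loosely. Without an aryl-on-carbonyl group of the kind that lowered the numbers, a modest move back toward compound 1 is expected, a 2.5-fold higher number from compound 3 to compound 4 (0.40 log units; beyond the scatter). The expected value for compound 4 is 50000 nM, within 15000 nM to 200000 nM.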

Compound 4, half-maximal inhibitory concentration: 12000 nM
For compound 4 the middle estimate is 4.2-fold (0.62 log units) above the measured one; the measured number lies below the stated range.
By their numbers in this assay, from the lowest: compounds 4, 3 and 2 (each within the scatter of the next, the first and the last beyond it); then compound 1.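

In this assay the amine nitrogen accepts a sulfonyl in place of a carbonyl, with a 1.7-fold lower number from compound 3 to compound 4 (0.22 log units; within the scatter) and so no separation from the benzofuran amide. Against the other two amides the same group gives a 2.2-fold lower number from compound 2 to compound 4 (0.34 log units; beyond the scatter) and a 9.8-fold lower number from compound 1 to compound 4 (0.99 log units; beyond the scatter), so a carbonyl is not needed at this place for numbers as low as that of compound 3. Nothing measured here explains this result.

The aryl group and the linking group change together in each of these steps, so their shares cannot be separated. A 4-methylbenzoyl or a phenylsulfonyl group on the same nitrogen would bear on that.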